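Methyl in Place of Hydroxy: Expected Cytotoxicity of Compound 4

The source may hold more compounds than are shown below. What is called first, only, known or untested is meant among the compounds shown, and "the series" means these compounds.

Measured in an ADME assay on NIH3T3 cells (Mus musculus) for cytotoxicity, read by XTT assay, with a stated time of 24 h; a lower number here means a stronger inhibitor, a higher number a weaker inhibitor:
Compound 1 `Cn1nnnc1SCC(=O)N/N=C/c1ccccc1` gives 9700000 nM.
Compound 2 `Cn1nnnc1SCC(=O)N/N=C/c1ccccc1Br` gives 20000 nM.
Compound 3 `Cn1nnnc1SCC(=O)N/N=C/c1ccccc1O` gives only a limit, > 10000000 nM.

Compound 3 thus stands at the limit of > 10000000 nM in this assay, at which 1 of the 3 values shown sits, a limit and not a number. Going by the values given here, two measured steps bear on it. Hydroxy in place of hydrogen gave an at least 1.0-fold higher number from compound 1 to compound 3 (0.01 log units; that floor lies within the scatter), a change within the scatter. Hydroxy in place of bromo gave an at least 500-fold higher number from compound 2 to compound 3 (2.69 log units; beyond the scatter), a large one. Compound 4 `Cc1ccccc1/C=N/NC(=O)CSc1nnnn1C` carries methyl in place of hydroxy on an aromatic carbon. Among the compounds with values here, no measured step swaps hydroxy for methyl, so the hydrogen and bromo cases frame the guess: methyl is expected to land nearer the hydrogen case, giving an expected step of an at least 2.5-fold lower number from compound 3 to compound 4 (0.39 log units; beyond the scatter) in this assay. Compound 4 is therefore estimated at 4000000 nM, with a range from 500000 nM to 10000000 nM.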

Compound 4, half-maximal inhibitory concentration: 6320000 nM
For compound 4 the middle estimate is 1.6-fold (0.20 log units) below the measured one; the range from low to high includes it.
By their numbers in this assay, from the lowest: compound 2; then compounds 4 and 1 (each within the scatter of the next). At a limit, above all of these: compound 3.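

At this place on the ring, methyl reads like hydrogen rather than bromo in this assay: the change is a 1.5-fold lower number from compound 1 to compound 4 (0.19 log units; within the scatter), whereas it is a 320-fold higher number from compound 2 to compound 4 (2.50 log units; beyond the scatter). Against hydroxy, the step is only a floor, an at least 1.5-fold lower number from compound 3 to compound 4 (0.19 log units; that floor lies within the scatter). Compound 3 remains a limit and not a number: the limit of > 10000000 nM in this assay, at which 1 of the 4 values shown sits.

The compounds shown leave open whether chloro or fluoro would give a low number as bromo does, and where an amine or a carboxylic acid would fall at this place.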